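The source may report more compounds than this note shows. Statements on the series, on what has been measured and on what is new or still open speak of the compounds shown alone.

Measured so far:
compound 1 `O=C1C=C(N2CCC2)C(=O)c2c1nc1n2[C@H]2OC[C@@H](O)[C@H]2OC1`, in a functional assay on ECa-109 cells for inhibition, with ECa-109 cell line (Homo sapiens) as the target, read by sulforhodamine B assay (a lower number here means a stronger inhibitor, a higher number a weaker inhibitor), compound 1 gives > 16000 nM, a limit of the assay.
compound 2 `O=C1C=C(NC2CCCC2)C(=O)c2c1nc1n2[C@H]2OC[C@@H](O)[C@H]2OC1`, in this assay compound 2 gives > 16000 nM, also a limit.
compound 3 `CCOc1ccc(NC2=CC(=O)c3nc4n(c3C2=O)[C@H]2OC[C@@H](O)[C@H]2OC4)cc1`, in this assay compound 3 gives 3210 nM.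

Going by the values given here, compound 3 stands as the only real number here, since the other two values sit at the limit of > 16000 nM in this assay, at which 2 of the 3 values shown sit. The step that the two limits leave unreadable from compound 1 to compound 2 cannot be read. The step of an at least 4.9-fold lower number from compound 2 to compound 3 (0.69 log units; beyond the scatter) is the only readable one and bears on the change at hand. Compound 4 `COc1cccc(NC2=CC(=O)c3nc4n(c3C2=O)[C@H]2OC[C@@H](O)[C@H]2OC4)c1` differs from compound 3 in one place: 3-methoxyphenyl in place of 4-ethoxyphenyl on an amine nitrogen. Both are aryl groups on the amine nitrogen, so no step beyond the scatter is expected in this assay. Compound 4 is expected at 3500 nM, between 1200 nM and 11000 nM. The expected step is a 1.1-fold higher number from compound 3 to compound 4 (0.04 log units; within the scatter).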

Compound 4, half-maximal inhibitory concentration: 7620 nM
Beside the measured number, compound 4's estimate is 2.2-fold (0.34 log units) below it; low and high end bracket the measured number.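

In this assay, the aryl group on the amine nitrogen is not interchangeable: 3-methoxyphenyl in place of 4-ethoxyphenyl gives a 2.4-fold higher number from compound 3 to compound 4 (0.38 log units; beyond the scatter). Compound 4 still reads stronger than both non-aryl amines, with an at least 2.0-fold lower number from compound 2 to compound 4 (0.32 log units; beyond the scatter) and an at least 2.0-fold lower number from compound 1 to compound 4 (0.32 log units; beyond the scatter). Compound 1 and compound 2 each stand at a limit of the assay, not at a number: the limit of > 16000 nM in this assay, at which 2 of the 4 values shown sit.

This change alters the name of the ether chain and its place on the ring together, and the two effects stay unseparated. A 4-methoxyphenyl group on the same amine nitrogen would separate them.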